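Halogen swap on the chlorophenoxy ring, cytotoxicity notes

A few compounds are considered here, and "the series" means these few. Any claim that something is new, unique, unknown or untested is made for them only; others in the source may bear on it.

Measured so far:
compound 1 `Cc1cc(S(N)(=O)=O)ccc1NC(=O)COc1ccc(Cl)cc1Oc1ccc2ccccc2c1`: 119000 nM
compound 2 `Cc1cc(S(N)(=O)=O)ccc1NC(=O)COc1ccc(Cl)cc1Oc1ccc2ccccc2c1Br`: 48100 nM
compound 3 `Cc1cc(S(N)(=O)=O)ccc1NC(=O)COc1ccc(F)cc1Oc1c(C)cc2ccccc2c1Cl`: 55600 nM

In an ADME assay on C8166 cells (Homo sapiens) for cytotoxicity, read by MTT assay (on this read-out higher numbers stand for lower toxicity in this test and lower numbers for higher toxicity in this test), compound 3 gives 55600 nM, the second highest of the three numbers. For the measured compounds named here, its nearest neighbour is compound 2, whose 48100 nM lies within the scatter of it; compound 1, with 119000 nM, stands beyond the scatter on the high side, so compound 1 is the only measured member clearly less toxic than compound 3.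

Compound 4 `Cc1cc(S(N)(=O)=O)ccc1NC(=O)COc1ccc(Cl)cc1Oc1c(C)cc2ccccc2c1Cl` differs from compound 3 by chloro in place of fluoro on an aromatic carbon. Going by the values given here, no measured pair shows this exact exchange. Among the compounds with values here, the only step recorded on the series is a 2.5-fold lower number from compound 1 to compound 2 (0.39 log units; beyond the scatter), a halogen entering an aromatic carbon elsewhere in the molecule; it is modest and points downward. A fluoro-to-chloro swap is a smaller change than adding a halogen where there was none, so in this assay the step of a 1.2-fold lower number from compound 3 to compound 4 (0.09 log units; within the scatter) is expected to stay within or only just beyond the scatter, if anything toward a lower number. Compound 4 is therefore estimated at 45000 nM, with a range from 20000 nM to 100000 nM.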

Compound 4, half-maximal cytotoxic concentration: 42600 nM
Compound 4: the middle estimate sits 1.1-fold (0.02 log units) above what was measured; low and high end bracket the measured number.
By their numbers in this assay, from the lowest: compounds 4, 2 and 3 (each within the scatter of the next); then compound 1.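

In this assay, for the compounds shown here, the first exchange on the halogen-bearing ring, chloro in place of fluoro on an aromatic carbon meta to a large group and para to a large group, gives a 1.3-fold lower number from compound 3 to compound 4 (0.12 log units; within the scatter) and so leaves the number within the scatter at this position. On the naphthalene side, 1-chloro-3-methylnaphthalen-2-yl in place of 1-bromonaphthalen-2-yl gives a 1.1-fold lower number from compound 2 to compound 4 (0.05 log units; within the scatter) and stays within the scatter, whereas the same group in place of naphthalen-2-yl gives a 2.8-fold lower number from compound 1 to compound 4 (0.45 log units; beyond the scatter) and lies beyond it. Nothing available accounts for either result.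

Going by these compounds, what a methoxy group or an amine on this aromatic carbon would do to the number stays open. Also open, on these data alone, is whether the fluoro-to-chloro exchange reads the same with an unsubstituted naphthalen-2-yl group on the oxygen.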